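Three Anilides on One Shared Core: How Much Cells Tolerate

A few compounds are considered here, and "the series" means these few. Any claim that something is new, unique, unknown or untested is made for them only; others in the source may bear on it.

Measured in an ADME assay on HepG2 cells (Homo sapiens) for cytotoxicity, read by trypan blue exclusion, with a stated time of 48 h, in the presence of a further agent that is not named here; a higher number here means that more compound is tolerated, a lower number that less compound is tolerated:
- compound 1 `COc1cccc(NC(=O)COc2cc(C)nc3ccc(OC)cc23)c1` gives 43000 nM.
- compound 2 `COc1ccc(NC(=O)COc2cc(C)nc3ccc(OC)cc23)cc1` gives > 142000 nM, which is a limit of the assay rather than a number.
- compound 3 `COc1ccc2nc(C)cc(OCC(=O)Nc3ccccc3Cl)c2c1` gives > 140000 nM, again a limit of the assay rather than a number.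

All three compounds share the same core and differ only in the aromatic ring attached to the amide-type nitrogen. Among the compounds with values here, compound 1, carrying a 3-methoxyphenyl there, is the only one with a true number in this assay. Compound 2 stands at the limit of > 142000 nM in this assay, at which 1 of the 3 values shown sits. Compound 3 stands at the limit of > 140000 nM in this assay, at which 1 of the 3 values shown sits, so its position is known only as a floor, not as a point.

Two steps are readable: an at least 3.3-fold higher number from compound 1 to compound 2 (0.51 log units; beyond the scatter) and an at least 3.2-fold higher number from compound 1 to compound 3 (0.51 log units; beyond the scatter). The step that the two limits leave unreadable from compound 2 to compound 3 cannot be sized, since both ends are limits.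

Compound 4 `COc1ccc2nc(C)cc(OCC(=O)Nc3ccc(C)cc3)c2c1` has not been measured. The change from compound 3 is 4-methylphenyl in place of 2-chlorophenyl on an amide-type nitrogen. Within the data shown here, no measured step involves a methyl on that ring, but the one other ring bearing a small substituent at the 4-position, in compound 2, also sits at the limit. Compound 4 is therefore expected to stay near the limit, with a step of about an at least 1.1-fold lower number from compound 3 to compound 4 (0.06 log units; that floor lies within the scatter). The estimate for compound 4 in this assay is 120000 nM, expected between 40000 nM and 200000 nM.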

Compound 4, half-maximal cytotoxic concentration: > 149000 nM
Compound 4 was reported as a limit (the forecaster's own chance of this, stated with the estimate: 55%); at least 1.2-fold (0.09 log units) between middle value and limit.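

In this assay, compound 4 also gives a limit of the assay rather than a number: the limit of > 149000 nM in this assay, at which 1 of the 4 values shown sits. This adds a ring whose only substituent is a methyl, so in these compounds neither the oxygen of a methoxy group nor a chlorine is needed for a value to reach the limit, while compound 1 remains the one exception, with an at least 3.4-fold higher number from compound 1 to compound 4 (0.53 log units; beyond the scatter). Among compound 2, compound 3 and compound 4, the steps cannot be read, so these three rings cannot be placed in any order and their true tolerated concentrations may be close together or far apart.

The compounds shown leave open whether the lower number of compound 1 depends on where the methoxy group sits on the ring or on the methoxy group itself, since no other ring here carries a substituent at that place. They also leave open how this assay would respond to a ring bearing an amine or a carboxylic acid in place of the methyl, as every ring here carries only a methoxy, a methyl or a chlorine.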